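The compounds below may be only part of what the source reports. "The series", "measured", "known", "first", "only" and "open" are said of these compounds alone.

Working notes on the series. Compound 1 `OC[C@H](NC1CCN(CCCc2c[nH]c3ccc(-n4ccnc4)cc23)CC1)c1ccccc1` gives 74% in a functional assay on CHO cells for activation of 5-hydroxytryptamine receptor 1D (Homo sapiens), read by GTPgammaS binding (on this read-out higher numbers stand for larger maximal responses and lower numbers for smaller maximal responses), the lowest of the three numbers measured. Compound 2 `CC(=O)Nc1ccc([C@H](C)NCC2CCN(CCCc3c[nH]c4ccc(-n5cnnc5)cc34)CC2)cc1` gives 99% and compound 3 `OCCC(NC1CCN(CCCc2c[nH]c3ccc(-n4cnnc4)cc23)CC1)c1ccccc1` gives 100%; both sit beyond the scatter above compound 1, and neither differs from it in only one place, so their values show only that higher efficacy is reached elsewhere in the series. Compound 4 `OC[C@H](NC1CCN(CCCc2c[nH]c3ccc(Cn4cncn4)cc23)CC1)c1ccccc1` differs from compound 1 by (1H-1,2,4-triazol-1-yl)methyl in place of 1H-imidazol-1-yl on an aromatic carbon. Among the compounds with values here, no single-point step is available to size this change. Compound 4 is expected to show a modest rise, a number 10 percentage points higher from compound 1 to compound 4 (within the scatter), not clearly beyond the scatter. Compound 4 is estimated at 84%, with a range of 66% to 100%.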

Compound 4, largest response reached (reported as efficacy), in percent of the reference or control that the assay uses: 76%
Estimate against measurement, compound 4: 8 percentage points above; measured number inside the range.
By their numbers in this assay, from the lowest: compounds 1 and 4 (each within the scatter of the next); then compounds 2 and 3 (each within the scatter of the next).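

At this aromatic carbon of the core of compound 1, (1H-1,2,4-triazol-1-yl)methyl in place of 1H-imidazol-1-yl gives a number 2 percentage points higher from compound 1 to compound 4 (within the scatter) in this assay. This first single-place step therefore does not separate the two groups on maximal response, despite the different ring and the added heavy atom. Nothing available bears on why the two groups do not separate.

From the compounds shown here alone, this step changes the ring and its attachment together, so the contribution of each stays open. Also open, going by these compounds, is how a carboxylic acid or a primary amine at this carbon would read out on the same core.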